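Cyanomethyl series: methoxy to hydroxy, compound 3 to compound 4

A few compounds are considered here, and "the series" means these few. Any claim that something is new, unique, unknown or untested is made for them only; others in the source may bear on it.

Of the compounds shown here, three have been read in a functional assay on UO-31 cells (Homo sapiens) for cytotoxicity, read by sulforhodamine B assay, with a stated time of 48 h, tested at 0.001 uM; on this read-out lower numbers stand for a stronger effect and higher numbers for a weaker effect at the one concentration tested. Compound 1 `COc1cc(C)cc(-c2c(-c3ccnc(-c4ccc(C(C)=O)cc4)c3)cnn2CC#N)c1` gives 88%. Compound 2 `Cc1cc(O)cc(-c2nn(CC#N)cc2-c2ccnc(-c3ccc(Oc4ccccc4)cc3)c2)c1` gives 91%. Compound 3 `COc1cc(C)cc(-c2nn(CC#N)cc2-c2ccnc(-c3ccc(N(C)C)cc3)c2)c1` gives 90%. Compound 3 holds the second highest of the three numbers; its nearest neighbour is compound 2 and its furthest is compound 1, both gaps within the usual scatter. No two of these compounds differ in a single place, so no step between measured compounds can be drawn; compound 1 carries a methoxy group and compound 2 a hydroxy group on the same ring, but they differ elsewhere too, and their two numbers lie close together.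

Compound 4 `Cc1cc(O)cc(-c2nn(CC#N)cc2-c2ccnc(-c3ccc(N(C)C)cc3)c2)c1` has not yet been measured. It differs from compound 3 as follows: hydrogen in place of methyl on an oxygen on an aromatic ring. The change is small, a single carbon leaving and a hydrogen entering on the oxygen of the aromatic ring.

Within the data shown here, nothing among the measured numbers points to movement beyond the scatter for this change, and all three values sit near the upper end. The step from compound 3 to compound 4 in this assay is therefore expected to be no change at the digits printed from compound 3 to compound 4 (within the scatter), that is, none beyond the scatter. Compound 4 is estimated at 90%, within a range from 82% to 98%.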

Compound 4, a percentage reported as activity, at one concentration (the size of the read-out at that concentration, not a potency): 89%
Compound 4: middle estimate off by 1 percentage points, on the high side, and the stated range covers the measured number.
By their numbers in this assay, from the lowest: compounds 1, 4, 3 and 2 (each within the scatter of the next).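

In this assay, the change from methoxy to hydroxy gives the series its first reading of this position in which nothing else differs: a number 1 percentage points lower from compound 3 to compound 4 (within the scatter). With the dimethylamino group held constant, the 3-methoxy-5-methylphenyl and 3-hydroxy-5-methylphenyl compounds therefore cannot be told apart on this read-out at the one concentration tested. The second single-place comparison, dimethylamino in place of phenoxy on an aromatic carbon, gives a number 2 percentage points lower from compound 2 to compound 4 (within the scatter), so with the hydroxy group held constant this exchange also stays within the scatter. No measurement is available that bears on the reason for either reading.

The compounds shown leave open whether an amino group or a carboxylic acid on the same aromatic ring, in place of the hydroxy group, would give a step beyond the scatter. As all four compounds were read at a single concentration, they also leave open whether methoxy and hydroxy would separate under conditions where the read-out lies far from these values.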